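Cyclohexyl for propyl on the compound 3 scaffold

The source may hold more compounds than are shown below. What is called first, only, known or untested is meant among the compounds shown, and "the series" means these compounds.

Values in a functional assay on brain (Rattus norvegicus, strain Wistar) for inhibition (on this read-out higher numbers stand for weaker inhibition and lower numbers for stronger inhibition), so far:
- compound 1 (`CCCc1ccc(-c2c(C)[nH]c(=O)n2C)cc1`) gives 21500 nM
- compound 2 (`CCCCCCCCCCCCCCCCCCc1ccc(-c2c(C)[nH]c(=O)n2C)cc1`) gives > 100000 nM as a limit of the assay, not a number
- compound 3 (`CCCc1ccc(-c2c(C)[nH]c(=O)n2C2CCCCC2)cc1`) gives 13900 nM

Compound 3 carries the lower of the two actual numbers, but compound 1 lies within the scatter of it, and the remaining entry is a limit. Compound 4 (`Cc1[nH]c(=O)n(C2CCCCC2)c1-c1ccc(C2CCCCC2)cc1`) departs from compound 3 by one change (cyclohexyl in place of propyl on an aromatic carbon), cyclohexyl in place of propyl on an aromatic carbon, para to a large group.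

Among the compounds with values here, the one measured step (a 1.5-fold lower number from compound 1 to compound 3 (0.19 log units; within the scatter)) put cyclohexyl in place of methyl on an aromatic nitrogen, which is a different place from the present change, and it stayed within the scatter. Within the data shown here, the aromatic carbon in question has otherwise been varied only in compound 2, whose octadecyl group ends at a limit (the limit of > 100000 nM in this assay, at which 1 of the 3 values shown sits) and so gives no size of step.

With so little to go on, no step beyond the scatter is expected in this assay for this change. The expected step is small (a 1.3-fold lower number from compound 3 to compound 4 (0.10 log units; within the scatter)) and its direction is uncertain. For compound 4 the estimated value is 11000 nM (expected range 3500 nM to 35000 nM).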

Compound 4, half-maximal inhibitory concentration: 28900 nM
Beside the measured number, compound 4's estimate is 2.6-fold (0.42 log units) below it, within the range that was stated.
By their numbers in this assay, from the lowest: compounds 3, 1 and 4 (each within the scatter of the next, the first and the last beyond it). At a limit, above all of these: compound 2.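

In this assay, the aromatic carbon that held propyl now has its first readable step, as cyclohexyl takes the place of propyl: a 2.1-fold higher number from compound 3 to compound 4 (0.32 log units; beyond the scatter). Within the data shown here, this modest step lies beyond the scatter, whereas the earlier change on the aromatic nitrogen stayed within it, so among the two readable steps only the one on this carbon moves the number by more than the scatter. The only other group shown on this carbon is the octadecyl of compound 2, on the core of compound 1, and compound 2 stands at a limit, not a number: the limit of > 100000 nM in this assay, at which 1 of the 4 values shown sits.

Propyl and cyclohexyl alone do not separate the presence of a ring from the larger count of carbons, so a hexyl chain or a phenyl ring on this carbon would be needed to tell the two apart, and an amine or a carboxylic acid at the end of such a chain remains unexplored. Among these compounds, it also remains open whether the same step appears with methyl in place of cyclohexyl on the aromatic nitrogen, as the single step rests on one nitrogen substituent.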